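Lengthening the Ether Chain on the Amine

The compounds below may be only part of what the source reports. "The series", "measured", "known", "first", "only" and "open" are said of these compounds alone.

Measured so far:
Compound 1 `CCCCCn1c(-c2ccco2)nc2c(N)ccnc21`: in an assay on isolated protein for inhibition of high affinity 3',5'-cyclic-AMP phosphodiesterase 7A (Homo sapiens), read by cAMP accumulation, with a stated time of 20 min (on this read-out lower numbers stand for stronger inhibition and higher numbers for weaker inhibition), compound 1 gives > 200000 nM, which is a limit of the assay and not a number.
Compound 2 `CCCCCn1c(-c2ccco2)nc2c(NCCOC)ccnc21`: in this assay compound 2 gives > 200000 nM, again a limit and not a number.

Compound 2 therefore stands only at a limit; both values shown sit at the same limit (the limit of > 200000 nM in this assay, at which 2 of the 2 values shown sit). The step that the two limits leave unreadable from compound 1 to compound 2 is left unreadable by those two limits, so it tells nothing about size or direction.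

Compound 3 `CCCCCn1c(-c2ccco2)nc2c(NCCCOC)ccnc21` differs from compound 2 by methoxymethyl in place of methoxy on a saturated chain carbon, two bonds along the chain from a nitrogen on an aromatic ring. For the measured compounds named here, no measured step bears readably on this change. With compound 2 at a limit and no readable step to build on, the expectation for compound 3 is that this assay again reports only a limit, and the expected step that the limit leaves unreadable from compound 2 to compound 3 is none beyond the scatter. Compound 3 is thus estimated at 300000 nM, within a range from 100000 nM to 1000000 nM.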

Compound 3, half-maximal inhibitory concentration: 34200 nM
The estimate for compound 3 lay 8.8-fold (0.94 log units) above the measured number; the measured number lies below the stated range.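

In this assay, for the compounds shown here, going from 2-methoxyethyl to 3-methoxypropyl on the amine gives the first readable step in this set, an at least 5.8-fold lower number from compound 2 to compound 3 (0.76 log units; beyond the scatter). Measured against a plain hydrogen on that nitrogen, the 3-methoxypropyl group gives an at least 5.8-fold lower number from compound 1 to compound 3 (0.76 log units; beyond the scatter). The length of the ether chain therefore matters at this position, although the step from hydrogen to 2-methoxyethyl cannot be read and the true size of both readable steps stays hidden, because only compound 3 has a number rather than a limit: the limit of > 200000 nM in this assay, at which 2 of the 3 values shown sit.

A longer chain such as 4-methoxybutyl might lower the number further or might not. As far as these compounds go, it also remains open whether the ether oxygen itself counts, which a plain butyl chain would test, or whether an amine or a carboxylic acid at the chain end would serve in its place.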